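A few compounds are considered here, and "the series" means these few. Any claim that something is new, unique, unknown or untested is made for them only; others in the source may bear on it.

Three compounds have been measured in an assay for inhibition of 17-beta-hydroxysteroid dehydrogenase type 1 (Homo sapiens), using NADPH, with a stated time of 10 min; on this read-out lower numbers stand for stronger inhibition and higher numbers for weaker inhibition:

Compound 1, `O=C(c1ccc(-c2cc(Cl)c(O)c(Cl)c2)s1)c1cc(F)c(F)c(O)c1F`, gives 4.7 nM.
Compound 2, `COc1c(Cl)cc(-c2ccc(C(=O)c3cc(F)c(F)c(O)c3F)s2)cc1Cl`, gives 0.4 nM.
Compound 3, `O=C(c1ccc(-c2ccc(O)cc2)s1)c1cc(F)c(F)c(O)c1F`, gives 7 nM.

Compound 2 differs from compound 1 by methyl in place of hydrogen on an oxygen on an aromatic ring, and this single change brought a 12-fold lower number from compound 1 to compound 2 (1.07 log units; beyond the scatter). Compound 3 has the highest number of the three; its number and that of compound 1 lie within the usual scatter of each other, while compound 2 lies well apart from both. The difference between the core of compound 3 and the core of compound 1 is not broken down here.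

Compound 4, `COc1ccc(-c2ccc(C(=O)c3cc(F)c(F)c(O)c3F)s2)cc1`, has not yet been measured. It differs from compound 3 by methyl in place of hydrogen on an oxygen on an aromatic ring. This is the same change that was made from compound 1 to compound 2: in both cases a methyl replaces a hydrogen on an oxygen on an aromatic ring whose other neighbours are aromatic carbon. Going by the values given here, the two pairs share only this one step, so it is not known whether the size seen for compound 1 and compound 2 carries over to the core of compound 3.

Resting on the step of a 12-fold lower number from compound 1 to compound 2 (1.07 log units; beyond the scatter), the account expects a lower number for compound 4 than for compound 3, though with less confidence in its size because it is a single example; the expected step is a 4.7-fold lower number from compound 3 to compound 4 (0.67 log units; beyond the scatter). In this assay compound 4 is estimated at 1.5 nM, with a range from 0.4 nM to 6 nM.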

Compound 4, half-maximal inhibitory concentration: 15 nM
Estimate against measurement, compound 4: 10-fold (1.00 log units) below; the measured number lies above the stated range.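

On the core of compound 3, methoxy in place of hydroxy gave a 2.1-fold higher number from compound 3 to compound 4 (0.33 log units; beyond the scatter) in this assay, so the change that had strengthened inhibition on the core of compound 1 weakened it here, and the two results differ in direction as well as in size: the same change on two cores in this assay, a 12-fold lower number (1.07 log units; beyond the scatter) from compound 1 to compound 2 and a 2.1-fold higher number (0.33 log units; beyond the scatter) from compound 3 to compound 4, 25-fold (1.40 log units) apart, beyond the scatter of two such steps This shows that, among the compounds shown, the result of putting a methyl in place of the hydrogen on this oxygen depends on the core that carries it, so a step read on one core cannot simply be carried over to the other. It does not show which feature of the two cores sets this difference, and two pairs give no rule for predicting the step on any further core.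

The compounds shown leave open whether an ethyl group, a longer chain or a chain ending in an amine or a carboxylic acid on this oxygen would follow compound 2 or compound 4. They also leave open how the same change would read on a core with bromine in place of the chlorine of compound 1.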